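The compounds below may be only part of what the source reports. "The series", "measured", "known", "first", "only" and "open" are said of these compounds alone.

Compound 1, `O=C(NCc1cc(Cl)ccc1-n1cnnn1)[C@@H]1C[C@@H]2C[C@@H]2N1C(=O)[C@H](O)c1ccccc1`, gives 620 nM in a functional assay on a cell-free system (plasma, Homo sapiens), with a stated time of 3 min; a lower number here means a stronger inhibitor, a higher number a weaker inhibitor.
Compound 2, `O=C(NCc1cc(Cl)ccc1-n1cnnn1)[C@@H]1C[C@H]2C[C@H]2N1C(=O)[C@H](O)CC1CC1`, gives 850 nM in this assay.
Compound 3, `CC1(C[C@@H](O)C(=O)N2[C@@H]3C[C@@H]3C[C@H]2C(=O)NCc2cc(Cl)ccc2-n2cnnn2)CC1`, gives 1300 nM in this assay.

Compound 3 has the highest of the three numbers; compound 2 sits within the scatter of it, compound 1 beyond it. The change to compound 4, `O=C(NCc1cc(Cl)ccc1-n1cnnn1)[C@@H]1C[C@H]2C[C@H]2N1C(=O)[C@H](O)c1ccccc1`, is phenyl in place of (1-methylcyclopropyl)methyl on a saturated chain carbon bound to a carbonyl carbon and an oxygen on a saturated carbon. For the measured compounds named here, the only measured step at this position, a 1.5-fold higher number from compound 2 to compound 3 (0.18 log units; within the scatter), alters the same chain and stays within the scatter. Compound 1 carries the same phenyl group but differs from compound 4 in its core, so its value only hints that phenyl goes with a lower number. Compound 4 is therefore expected at 700 nM, between 350 nM and 1400 nM, a step of a 1.9-fold lower number from compound 3 to compound 4 (0.27 log units; within the scatter) that is estimated to reach just beyond the scatter.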

Compound 4, half-maximal inhibitory concentration: 680 nM
Compound 4: the middle estimate sits 1.0-fold (0.01 log units) above what was measured; measured number inside the range.
By their numbers in this assay, from the lowest: compounds 1, 4, 2 and 3 (each within the scatter of the next, the first and the last beyond it).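

On this chain carbon, phenyl cannot be told apart from the saturated groups: the result is a 1.9-fold lower number from compound 3 to compound 4 (0.28 log units; within the scatter) against (1-methylcyclopropyl)methyl and a 1.3-fold lower number from compound 2 to compound 4 (0.10 log units; within the scatter) against cyclopropylmethyl. So an aromatic ring is accepted here as well as those groups are. The configuration of the core also shows no readable effect with phenyl, at a 1.1-fold higher number from compound 1 to compound 4 (0.04 log units; within the scatter), and that comparison is a clean one: the fact that compounds 1 and 4 differ only in the configuration as drawn.

From the compounds shown here alone, whether an amine or a carboxylic acid on this carbon would reach beyond the scatter stays open. So does whether the configuration of the core matters with groups other than phenyl.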